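A few compounds are considered here, and "the series" means these few. Any claim that something is new, unique, unknown or untested is made for them only; others in the source may bear on it.

Measured in a physicochemical assay for solubility, read by spectrophotometry, in phosphate buffer, with a stated time of 2 h, at pH 7.4; a lower number here means a less soluble compound, a higher number a more soluble compound:
compound 1 `COc1cccc(CN2C(=O)CN(C(=O)c3cc4cc(OC)ccc4[nH]3)C[C@@H]2Cc2ccccn2)c1` gives 57900 nM.
compound 2 `COc1ccc2[nH]c(C(=O)N3CC(=O)N(Cc4ccccc4)[C@@H](COC(C)(C)C)C3)cc2c1` gives 65500 nM.
compound 3 `COc1ccc2[nH]c(C(=O)N3CC(=O)N(Cc4ccccc4)[C@@H](Cc4ccccn4)C3)cc2c1` gives > 100000 nM, which is a limit of the assay and not a number.

Compound 3 therefore stands at the limit of > 100000 nM in this assay, at which 1 of the 3 values shown sits, with no numerical value of its own. As far as these compounds go, the two measured steps that lead to it, an at least 1.7-fold higher number from compound 1 to compound 3 (0.23 log units; that floor lies within the scatter) and an at least 1.5-fold higher number from compound 2 to compound 3 (0.18 log units; that floor lies within the scatter), are floors that lie within the scatter, so the size of either change into compound 3 is unknown. Compound 4 `COc1ccc2[nH]c(C(=O)N3CC(=O)N(Cc4ccccc4)[C@@H](CN4CC5(CCC5)C4)C3)cc2c1` differs from compound 3 by a group of 7 heavy atoms (6 carbon, 1 nitrogen; one four-membered non-aromatic ring of carbon only, one four-membered non-aromatic ring with 1 hetero atom) in place of a group of 6 heavy atoms (5 carbon, 1 nitrogen; one six-membered aromatic ring with 1 hetero atom), on a saturated chain carbon bound to a saturated ring carbon. Going by the values given here, no measured step bears directly on this change; the pyridin-2-yl group has been varied only once, and only as a floor, so no direction beyond the scatter can be read from the data. In this assay compound 4 is estimated at 150000 nM (range 60000 nM to 400000 nM), an expected step that the limit leaves unreadable from compound 3 to compound 4, with a fair chance that again only a limit is reported.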

Compound 4, solubility: 60700 nM
The estimate for compound 4 lay 2.5-fold (0.39 log units) above the measured number; the measured number falls inside the stated range.
By their numbers in this assay, from the lowest: compounds 1, 4 and 2 (each within the scatter of the next). At a limit, above all of these: compound 3.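

In this assay the step at the saturated chain carbon bound to a saturated ring carbon, with the group with two four-membered rings in place of the tert-butoxy group, is a 1.1-fold lower number from compound 2 to compound 4 (0.03 log units; within the scatter) and does not separate the two groups. Going by these compounds alone, this is the first comparison at this position that yields a number rather than a floor. The step of an at least 1.6-fold lower number from compound 3 to compound 4 (0.21 log units; that floor lies within the scatter) is only a floor, so its size cannot be read. Compound 3 remains at a limit of the assay: the limit of > 100000 nM in this assay, at which 1 of the 4 values shown sits.

As far as these compounds go, whether pyridin-2-yl truly differs from either group at this position remains open. So does the outcome of placing a carboxylic acid or a primary amine on that chain carbon.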